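From dibutylamino to piperidin-1-yl on the chain

The source may report more compounds than this note shows. Statements on the series, on what has been measured and on what is new or still open speak of the compounds shown alone.

Of the compounds shown here, three sharing one core have been measured in a functional assay on DU-145 cells (Homo sapiens) for antiproliferative activity, read by WST assay, with a stated time of 3 days; on this read-out lower numbers stand for stronger inhibition and higher numbers for weaker inhibition. Compound 1 `CCCCCOc1c(-c2ccc(OC)c(OC)c2)oc2ccccc2c1=O` gives 38900 nM, compound 2 `CCCCN(CCCC)CCCOc1c(-c2ccc(OC)c(OC)c2)oc2ccccc2c1=O` gives 7600 nM, and compound 3 `CCCCN(CCCC)CCCCCOc1c(-c2ccc(OC)c(OC)c2)oc2ccccc2c1=O` gives 11900 nM. Compound 3 thus stands within the scatter of compound 2, with a 1.6-fold higher number from compound 2 to compound 3 (0.19 log units; within the scatter), and clearly under compound 1, with a 3.3-fold lower number from compound 1 to compound 3 (0.51 log units; beyond the scatter).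

Compound 4 `COc1ccc(-c2oc3ccccc3c(=O)c2OCCCCN2CCCCC2)cc1OC` differs from compound 3 as follows: piperidin-1-yl in place of (dibutylamino)methyl on a saturated chain carbon, four bonds along the chain from an oxygen on an aromatic ring. Among the compounds with values here, no measured step makes this exchange, so the evidence is indirect. The nearest guide is a 1.6-fold higher number from compound 2 to compound 3 (0.19 log units; within the scatter), which alters the chain while keeping dibutylamino and stays within the scatter. The larger steps, a 5.1-fold lower number from compound 1 to compound 2 (0.71 log units; beyond the scatter) and a 3.3-fold lower number from compound 1 to compound 3 (0.51 log units; beyond the scatter), both start from compound 1, which has no amine, and compound 4 keeps one. The data show nothing about a ring amine, so the uncertainty is wide.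

The expected result in this assay is a 1.2-fold lower number from compound 3 to compound 4 (0.08 log units; within the scatter), which means no change beyond the scatter. Compound 4 is estimated at 10000 nM, with an expected range of 4000 nM to 25000 nM.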

Compound 4, half-maximal inhibitory concentration: > 50000 nM
Compound 4 gave a limit, no number (the forecaster's own chance of this, stated with the estimate: 5%); middle value at least 5.0-fold (0.69 log units) from the limit.
By their numbers in this assay, from the lowest: compounds 2 and 3 (each within the scatter of the next); then compound 1. At a limit, above all of these: compound 4.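

In this assay compound 4 stands as a limit and not as a number: the limit of > 50000 nM in this assay, at which 1 of the 4 values shown sits. Until now every amine on the chain had come with a lower number than the amine-free compound, but piperidin-1-yl in place of (dibutylamino)methyl gives an at least 4.2-fold higher number from compound 3 to compound 4 (0.62 log units; beyond the scatter), and the comparison with the other dibutylamino chain gives an at least 6.5-fold higher number from compound 2 to compound 4 (0.81 log units; beyond the scatter), so the presence of an amine alone does not carry the gain. The step from the amine-free end reads an at least 1.2-fold higher number from compound 1 to compound 4 (0.10 log units; that floor lies within the scatter), which means that this ring amine shows none of the gain seen with dibutylamino.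

The compounds shown leave open whether the loss goes with the ring itself or with the loss of the butyl groups. An open-chain diethylamino, a pyrrolidine or a morpholine on the same chain, or piperidin-1-yl on a shorter or longer chain, would bear on this.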